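Para-substituent swap on the arylpiperazine of compound 2

The compounds below may be only part of what the source reports. "The series", "measured", "known", "first", "only" and "open" are said of these compounds alone.

Measured so far:
compound 1 `CCCc1nc(-c2ccccc2)c(CNCCCN2CCN(c3cccc(C)c3C)CC2)o1` — 1780 nM
compound 2 `CCCc1nc(-c2ccccc2)c(CNCCCN2CCN(c3ccc(C)cc3)CC2)o1` — 130000 nM

For the measured compounds named here, in an assay on HEK293 cells for inhibition of Voltage-dependent T-type calcium channel subunit alpha-1G (Homo sapiens), read by patch clamp (a lower number here means a stronger inhibitor, a higher number a weaker inhibitor), compound 2 gives 130000 nM, the highest of the two numbers; the only measured step, a 73-fold higher number from compound 1 to compound 2 (1.86 log units; beyond the scatter), concerned a different change. Compound 3 `CCCc1nc(-c2ccccc2)c(CNCCCN2CCN(c3ccc(Cl)cc3)CC2)o1` differs from compound 2 by chloro in place of methyl on an aromatic carbon. Going by the values given here, no measured step bears on chloro replacing methyl at this position, so for compound 3 a step of a 1.3-fold lower number from compound 2 to compound 3 (0.11 log units; within the scatter) is expected, within the usual scatter. The estimate for compound 3 in this assay is 100000 nM, with a range from 20000 nM to 500000 nM.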

Compound 3, half-maximal inhibitory concentration: 1310 nM
The estimate for compound 3 lay 76-fold (1.88 log units) above the measured number; measured number below the stated range.
By their numbers in this assay, from the lowest: compounds 3 and 1 (each within the scatter of the next); then compound 2.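

In this assay, the aromatic carbon para to a large group proved highly sensitive to one atom, with chloro in place of methyl giving a 99-fold lower number from compound 2 to compound 3 (2.00 log units; beyond the scatter). The 4-chlorophenyl group also matched the 2,3-dimethylphenyl group, with a 1.4-fold lower number from compound 1 to compound 3 (0.13 log units; within the scatter), so the weak reading of compound 2 belongs to 4-methylphenyl and not to every group at this position. Nothing available explains why chloro and methyl differ so sharply. As far as these compounds go, it remains open whether fluoro, bromo or methoxy at this position would read like chloro or like methyl.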